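Ethyl to propyl on the chain carbon of compound 2

The source may hold more compounds than are shown below. What is called first, only, known or untested is meant among the compounds shown, and "the series" means these compounds.

Measured so far:
compound 1 `CC[C@@H](c1ccc(C(=O)O)c(Oc2cccc(Cl)c2)c1F)N1CCC[C@H](n2cc(C)c(=O)[nH]c2=O)C1`: 0.11
compound 2 `CC[C@H](c1ccc(C(=O)O)c(Oc2cccc(Cl)c2)c1F)N1CCC[C@H](n2cc(C)c(=O)[nH]c2=O)C1`: 0.12

In a physicochemical assay for lipophilicity, using the shake flask method, in phosphate buffer, measured as octanol-water partition, at pH 7.4 (a higher number here means a more lipophilic compound, a lower number a more polar compound), compound 2 stands highest of the two numbers, with compound 1 nearest at a number 0.01 log units higher from compound 1 to compound 2 (within the scatter), the two being distinguished only by the fact that compounds 1 and 2 differ only in the configuration as drawn. Compound 3 `CCC[C@H](c1ccc(C(=O)O)c(Oc2cccc(Cl)c2)c1F)N1CCC[C@H](n2cc(C)c(=O)[nH]c2=O)C1` carries methyl in place of hydrogen on a saturated chain carbon, three bonds along the chain from an amine nitrogen in a ring and an aromatic carbon. For the measured compounds named here, no measured step involves such a change; the one step at hand is a configuration swap and does not bear on it. For compound 3 a step of a number 0.38 log units higher from compound 2 to compound 3 (beyond the scatter) is expected in this assay. Compound 3 is therefore estimated at 0.5, between 0.1 and 0.9.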

Compound 3, distribution coefficient: 0.53
Compound 3: middle estimate off by 0.03 log units, on the low side; measured number inside the range.
By their numbers in this assay, from the lowest: compounds 1 and 2 (each within the scatter of the next); then compound 3.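

Methyl in place of hydrogen on this saturated chain carbon gives a number 0.41 log units higher from compound 2 to compound 3 (beyond the scatter) in this assay and so moves the number beyond the scatter, unlike the configuration change in a number 0.01 log units higher from compound 1 to compound 2 (within the scatter) within the same series. This single step from ethyl to propyl shows that the chain length at this position registers in the read-out, but it does not establish a trend. Nothing at hand bears on the cause of this step.

As far as these compounds go, whether a butyl chain would extend the rise remains open. So does the effect of an ether oxygen or an amine in the chain at this place.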